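The source may hold more compounds than are shown below. What is called first, only, known or untested is meant among the compounds shown, and "the series" means these compounds.

Measured so far in a functional assay on LOX IMVI cells (Homo sapiens) for cytotoxicity, read by MTT assay, with a stated time of 24 h; on this read-out lower numbers stand for stronger inhibition and higher numbers for weaker inhibition:

- compound 1 `COc1cc(-c2nc(-c3ccccc3)[nH]c2-c2ccnc(NCCCNS(=O)(=O)c3ccc(F)cc3)n2)ccc1F` gives 3960 nM
- compound 2 `O=S(=O)(NCCCNc1nccc(-c2[nH]c(-c3ccccc3)nc2-c2ccc(F)c(O)c2)n1)c1ccccc1` gives 9580 nM
- compound 3 `O=S(=O)(NCCCNc1nccc(-c2[nH]c(-c3ccccc3)nc2-c2ccc(F)c(O)c2)n1)c1ccc(Cl)cc1` gives 14200 nM

Compound 3 lies within the scatter of compound 2, and its number is higher than that of compound 1. Compound 4 `O=S(=O)(NCCCNc1nccc(-c2[nH]c(-c3ccccc3)nc2-c2ccc(F)c(O)c2)n1)c1ccc(F)cc1` alters compound 3 in one place: fluoro in place of chloro on an aromatic carbon. For the measured compounds named here, the only measured step at that place, a 1.5-fold higher number from compound 2 to compound 3 (0.17 log units; within the scatter), put chloro in place of hydrogen and stayed within the scatter. Swapping chloro for fluoro is therefore expected to bring no change beyond the scatter in this assay. The expected step is a 1.3-fold lower number from compound 3 to compound 4 (0.11 log units; within the scatter). Compound 4 is estimated at 11000 nM, with an expected range from 5500 nM to 22000 nM.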

Compound 4, half-maximal inhibitory concentration: 19200 nM
For compound 4 the middle estimate is 1.7-fold (0.24 log units) below the measured one, within the range that was stated.
By their numbers in this assay, from the lowest: compound 1; then compounds 2, 3 and 4 (each within the scatter of the next).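

In this assay, fluoro in place of chloro on the aromatic carbon gives a 1.4-fold higher number from compound 3 to compound 4 (0.13 log units; within the scatter), and fluoro in place of hydrogen gives a 2.0-fold higher number from compound 2 to compound 4 (0.30 log units; within the scatter), so hydrogen, chloro and fluoro at this place all lie within the scatter of one another. For the compounds shown here, with the 4-fluorophenyl group held fixed, hydrogen in place of methyl on the oxygen gives a 4.8-fold higher number from compound 1 to compound 4 (0.69 log units; beyond the scatter), the only new step beyond the scatter. Nothing available explains these results. As far as these compounds go, whether an amine or a nitrile at this place would shift the number remains open.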